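The source may report more compounds than this note shows. Statements on the series, on what has been measured and on what is new or still open speak of the compounds shown alone.

Compound 1 `O=C(O)c1ccc(-n2cc(CO[C@H]3O[C@H](CO)[C@@H](O)[C@H](O)[C@@H]3O)nn2)cc1`: "not determined" (no result reported)
Compound 2 `O=C(O)c1cccc(-n2cc(CO[C@H]3O[C@H](CO)[C@@H](O)[C@H](O)[C@@H]3O)nn2)c1`: "not determined" (no result reported)
Compound 3 `COc1ccc(Cn2cc(CO[C@H]3O[C@H](CO)[C@@H](O)[C@H](O)[C@@H]3O)nn2)cc1`: -0.4

Within the data shown here, in a physicochemical assay for lipophilicity, read by LC-MS, using the shake flask method, in phosphate buffer, measured as octanol-water partition, with a stated time of 2 h, at pH 7.4 (on this read-out higher numbers stand for higher lipophilicity and lower numbers for lower lipophilicity), compound 3 gives -0.4 and this is the only number available. Among the measured compounds shown here, compound 1 and compound 2 have no reported result, so compound 3 cannot be ranked against them, and no measured pair offers a step to learn from.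

The next compound to be tested is compound 4 `O=[N+]([O-])c1ccc(-n2cc(CO[C@H]3O[C@H](CO)[C@@H](O)[C@H](O)[C@@H]3O)nn2)cc1`. It keeps the shared core but carries 4-nitrophenyl in place of 4-methoxybenzyl on an aromatic nitrogen. Both groups contain one six-membered aromatic ring of carbon only, while the link to the ring nitrogen and the substituent both change. For the measured compounds named here, with no measured example of this swap, the forecast starts from compound 3 at -0.4 and stays cautious. The expected change is a number 0.10 log units higher from compound 3 to compound 4 (within the scatter) in this assay and that means no step beyond the usual scatter is expected. Compound 4 is estimated at -0.3 with an expected range from -0.8 to 0.2 on this single reference point.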

Compound 4, distribution coefficient: -0.16
Beside the measured number, compound 4's estimate is 0.14 log units below it; the range from low to high includes it.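

In this assay, among these compounds, 4-nitrophenyl in place of 4-methoxybenzyl on an aromatic nitrogen gives a number 0.24 log units higher from compound 3 to compound 4 (within the scatter), the first step that can be read at this position. The swap alters both the link to the ring nitrogen and the substituent while keeping the same count of heavy atoms and one six-membered aromatic ring, yet this double change does not separate the two compounds on this read-out. No supporting measurement bears on this result.

From the compounds shown here alone, the two changes travelled together, so the effect of each alone stays open; 4-methoxyphenyl or 4-nitrobenzyl on the same nitrogen would pull them apart. Going by these compounds, compound 1 and compound 2 have no number, so their steps cannot be read, and it also remains open how an amine on the aromatic ring would read here.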